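The source may hold more compounds than are shown below. What is called first, only, known or untested is meant among the compounds shown, and "the series" means these compounds.

Working notes on the series. Within the data shown here, the two measured members share a core: compound 1 `CCCS(=O)(=O)N1CCN(C2(CNC(=O)c3ccc(OC(F)(F)F)cc3)CCCCC2)CC1` and compound 2 `CCCS(=O)(=O)N1CCN(C2(CNC(=O)c3cccc(C(F)(F)F)c3Cl)CCCCC2)CC1`. In an assay on JAR cells for inhibition of sodium- and chloride-dependent glycine transporter 1 (Homo sapiens), read by scintillation proximity assay (on this read-out lower numbers stand for stronger inhibition and higher numbers for weaker inhibition), compound 1 gives 118 nM, and in this assay compound 2 gives 77.9 nM. Among the measured compounds shown here, the single step between them, a 1.5-fold lower number from compound 1 to compound 2 (0.18 log units; within the scatter), lies within the scatter, so compound 2 and compound 1 cannot be told apart on these numbers; compound 2 merely has the lower of the two values shown, with compound 1 its only neighbour.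

Compound 3 `CCCS(=O)(=O)N1CCN(C2(CNC(=O)c3c(Cl)cccc3Cl)CCCCC2)CC1` is not yet measured in this assay. It differs from compound 2 in one place: 2,6-dichlorophenyl in place of 2-chloro-3-(trifluoromethyl)phenyl on a carbonyl carbon. For the measured compounds named here, the only measured step that bears on this change is the aryl exchange on the same carbonyl carbon, a 1.5-fold lower number from compound 1 to compound 2 (0.18 log units; within the scatter), which was within the scatter. No other aryl variation at this position has a number here. On that basis compound 3 is expected to sit close to compound 2, with an expected step of a 1.2-fold higher number from compound 2 to compound 3 (0.06 log units; within the scatter), none beyond the scatter. Compound 3 is therefore estimated at 90 nM, with a range from 35 nM to 250 nM.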

Compound 3, half-maximal inhibitory concentration: 12.8 nM
Estimate against measurement, compound 3: 7.0-fold (0.85 log units) above, outside the stated range (below it).
By their numbers in this assay, from the lowest: compound 3; then compounds 2 and 1 (each within the scatter of the next).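

In this assay, the aryl group on the carbonyl carbon proves able to shift the number beyond the scatter, which the earlier exchange on this carbon did not show: 2,6-dichlorophenyl gives a 6.1-fold lower number from compound 2 to compound 3 (0.78 log units; beyond the scatter) and, against the other aryl group, a 9.2-fold lower number from compound 1 to compound 3 (0.96 log units; beyond the scatter). Compound 3 is therefore the most potent of the three in this read-out, while the two groups it is compared with remain within the scatter of each other, so the result separates 2,6-dichlorophenyl from both rather than ranking all three aryl groups. Leaving and entering groups match in hydrogen-bond donors, hydrogen-bond acceptors and net charge, and nothing measured here accounts for the difference in potency.

Open, on these data alone, is whether both chlorines of 2,6-dichlorophenyl are needed, which unsubstituted phenyl, or methyl or fluorine in place of those chlorines, would help to settle. Also open, as far as these compounds go, is whether the gain carries over to a core with a shorter chain on the sulfonyl group, such as ethyl in place of propyl, since all three compounds share one core.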